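The source may report more compounds than this note shows. Statements on the series, on what has been measured and on what is new or still open speak of the compounds shown alone.

Measured compounds:
compound 1 `COc1ccc(CCCCCCCCOc2ccc(CSCc3cccc(C(=O)O)c3)nc2/C=C/C(=O)O)cc1` gives 271 nM
compound 2 `COc1ccc(CCCCCCCCOc2ccc(CS(=O)(=O)Cc3cccc(C(=O)O)c3)nc2/C=C/C(=O)O)cc1` gives 1000 nM
compound 3 `O=C(O)/C=C/c1nc(CSCc2cccc(C(=O)O)c2)ccc1OCCCCCCCCc1ccccc1` gives 500 nM

On a functional assay on the whole organism with Homo sapiens as the target (on this read-out lower numbers stand for stronger inhibition and higher numbers for weaker inhibition), compound 3 holds the second highest of the three numbers; compound 1 is nearest and compound 2 furthest, both within the scatter of compound 3. Compound 4 `COc1ccc(CCCCOc2ccc(CSCc3cccc(C(=O)O)c3)nc2/C=C/C(=O)O)cc1` differs from compound 3 by 4-methoxyphenyl in place of 4-phenylbutyl on a saturated chain carbon, four bonds along the chain from an oxygen on an aromatic ring. Among the measured compounds shown here, only one measured step bears on part of this change: a 1.8-fold higher number from compound 1 to compound 3 (0.27 log units; within the scatter), which covers the methoxy alone and lay within the scatter. For the measured compounds named here, the shortening of the chain has no measured counterpart in this assay, so its effect cannot be judged from the data. The step of a 1.6-fold higher number from compound 3 to compound 4 (0.20 log units; within the scatter) is therefore expected to be small to modest, direction uncertain. Compound 4 is estimated at 800 nM in this assay, with a range from 200 nM to 3500 nM.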

Compound 4, half-maximal inhibitory concentration: 770 nM
The estimate for compound 4 lay 1.0-fold (0.02 log units) above the measured number; the measured number falls inside the stated range.
By their numbers in this assay, from the lowest: compounds 1, 3, 4 and 2 (each within the scatter of the next, the first and the last beyond it).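

In this assay, among the compounds shown here, 4-methoxyphenyl in place of 4-(4-methoxyphenyl)butyl on a saturated chain carbon gives a 2.8-fold higher number from compound 1 to compound 4 (0.45 log units; beyond the scatter) and is the first change at this position beyond the scatter: with the methoxy kept, the shorter chain gives modestly weaker inhibition. By contrast, 4-methoxyphenyl in place of 4-phenylbutyl gives a 1.5-fold higher number from compound 3 to compound 4 (0.19 log units; within the scatter) and stays within the scatter, so this step alone would not show a chain-length effect.

Open, as far as these compounds go, are a longer chain than 4-(4-methoxyphenyl)butyl and a fluorine or an amine in place of the methoxy. The compounds shown also leave open whether chains of intermediate length follow the same trend. No measurement at hand explains either step.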